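Methyl for Methoxy at the Edge of the Series

The compounds below may be only part of what the source reports. "The series", "measured", "known", "first", "only" and "open" are said of these compounds alone.

Two compounds form the starting point. Compound 1, `Nc1nc(-c2ccc(Cc3ccc(C(F)(F)F)cc3)cc2)cs1`, carries a trifluoromethyl group, while compound 2, `COc1cccc(Cc2ccc(-c3csc(N)n3)cc2)c1`, carries a methoxy group instead. In an assay on cells for activation of leukotriene A-4 hydrolase (Homo sapiens), with a stated time of 10 min (a higher number here means that more compound is needed for the effect, a lower number that less compound is needed), compound 1 gives 1390 nM, and in the same assay compound 2 gives 5920 nM. Of the two numbers, compound 2 thus stands at the higher one, meaning more of it is needed, and the gap between the two values lies beyond the usual scatter of the measurement.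

The next compound, compound 3, `Cc1cccc(Cc2ccc(-c3csc(N)n3)cc2)c1`, has not yet been measured. It differs from compound 2 in one place only: methyl in place of methoxy on an aromatic carbon, on an aromatic carbon of a six-membered aromatic ring of carbon only. Among the compounds with values here, no measured pair shows the effect of this exchange, so the expectation rests on compound 2 alone.

The step from compound 2 to compound 3 is expected to be small, most likely within the scatter, with a slight lean toward a lower number, so the expected change is a 1.5-fold lower number from compound 2 to compound 3 (0.17 log units; within the scatter). For compound 3 in this assay the estimate is 4000 nM, with a range from 1500 nM to 11000 nM.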

Compound 3, concentration for half-maximal activity: 4810 nM
For compound 3 the middle estimate is 1.2-fold (0.08 log units) below the measured one; the range from low to high includes it.
By their numbers in this assay, from the lowest: compound 1; then compounds 3 and 2 (each within the scatter of the next).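

On the aromatic carbon meta to a large group, the exchange of methoxy for methyl gives a 1.2-fold lower number from compound 2 to compound 3 (0.09 log units; within the scatter) in this assay and so stays within the scatter of the measurement. Within the data shown here, this is the first measured step at this place, and it shows that the oxygen and the hydrogen-bond acceptor can leave with the methoxy group, and the smaller methyl group can enter, without a readable change in the number for this pair of compounds. The compounds shown offer no measured basis for explaining why this exchange leaves the number within the scatter.

One step at one place cannot show how far this result extends, and the same exchange may read differently on another carbon of the ring or in another assay. As far as these compounds go, what remains open is how a hydroxyl group, an amine, a carboxylic acid or a longer chain such as propyl would behave on this same aromatic carbon, and whether any of them would move the number beyond the scatter in either direction.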